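Amide swap from methylcyclohexyl to oxolane

This account rests on a few compounds, and the source may have more. Where it says the series, first, only, none or still open, it means among the compounds named here.

Compound 3 `CC1CCC(C(=O)N2CC(c3nc(-c4cccc(Cl)c4)no3)C2)CC1` was tested in an assay on HEK293 cells for negative allosteric modulation of metabotropic glutamate receptor 5 (Homo sapiens), read by FLIPR (on this read-out higher numbers stand for weaker inhibition and lower numbers for stronger inhibition), and there compound 3 gives > 10000 nM, a limit of the assay rather than a number. Compound 1 `O=C(c1ccc(Cl)cc1)N1CC(c2nc(-c3cccc(F)c3)no2)C1` likewise reaches only a limit, > 10000 nM. Compound 2 `O=C(C1CCCCC1)N1CC(c2nc(-c3cccc(F)c3)no2)C1` also stops at a limit, > 10000 nM. All three measurements sit at the limit of > 10000 nM in this assay, at which 3 of the 3 values shown sit. The step that the two limits leave unreadable from compound 1 to compound 2 therefore cannot be read. Compound 4 `O=C(C1CCCO1)N1CC(c2nc(-c3cccc(Cl)c3)no2)C1` differs from compound 3 by oxolan-2-yl in place of 4-methylcyclohexyl on a carbonyl carbon. Among the compounds with values here, no measured step shows how a change at this carbonyl carbon moves the read-out, since every comparison so far ends at the same limit. Compound 4 is therefore expected to remain near that limit, a step that the limit leaves unreadable from compound 3 to compound 4 of nothing readable beyond the scatter. The estimate for compound 4 is 15000 nM, between 4000 nM and 60000 nM.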

Compound 4, half-maximal inhibitory concentration: 890 nM
Compound 4: the middle estimate sits 17-fold (1.23 log units) above what was measured; the measured number lies below the stated range.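

This carbonyl carbon is a place where the read-out can move: in this assay, oxolan-2-yl in place of 4-methylcyclohexyl gives an at least 11-fold lower number from compound 3 to compound 4 (1.05 log units; beyond the scatter). The earlier compounds could not show this, and the step from compound 1 to compound 2 cannot be read, because their values stop at one limit: the limit of > 10000 nM in this assay, at which 3 of the 4 values shown sit.

The change swaps a six-membered carbon ring for a five-membered ring with one hydrogen-bond acceptor. From the compounds shown here alone, whether the ring oxygen or the ring size matters remains open, as does how pyrrolidin-2-yl, an amine, or a longer chain such as methoxyethyl would behave on this carbonyl carbon.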